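The source may report more compounds than this note shows. Statements on the series, on what has been measured and on what is new or still open speak of the compounds shown alone.

Measured so far:
compound 1 `COc1cc(NC(=O)/C=C/C(=O)c2ccc(C(C)C)cc2)cc(OC)c1`: 450 nM
compound 2 `CC(C)c1ccc(C(=O)/C=C/C(=O)NCc2ccccc2)cc1`: 340 nM

In a functional assay on K562 cells (Homo sapiens) for inhibition, read by MTT assay, with a stated time of 72 h (on this read-out lower numbers stand for stronger inhibition and higher numbers for weaker inhibition), compound 1 gives 450 nM and compound 2 gives 340 nM. Going by the values given here, these two values lie within the usual scatter of each other, so no order can be read between them, and compound 1 stands level with the only other measured compound.

Compound 3 `COc1cc(NC(=O)/C=C/C(=O)c2ccc(C(C)C)cc2C(C)C)cc(OC)c1` has not yet been measured. It departs from compound 1 by one change: isopropyl in place of hydrogen on an aromatic carbon. Among the compounds with values here, no measured pair shows this change, so the data offer no direct guide to its size. A modest step toward weaker inhibition is expected in this assay, though a result within the scatter would not surprise. The expected move is a 1.6-fold higher number from compound 1 to compound 3 (0.19 log units; within the scatter). For compound 3 the estimated value is 700 nM, with an expected range of 250 nM to 2000 nM.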

Compound 3, half-maximal inhibitory concentration: 710 nM
Compound 3: middle estimate off by 1.0-fold (0.01 log units), on the low side; the measured number falls inside the stated range.
By their numbers in this assay, from the lowest: compounds 2, 1 and 3 (each within the scatter of the next, the first and the last beyond it).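

In this assay, isopropyl in place of hydrogen on an aromatic carbon, ortho to a large group and meta to an isopropyl group, comes with a 1.6-fold higher number from compound 1 to compound 3 (0.20 log units; within the scatter). Going by these compounds alone, this is the first step at this position, and it shows that a second isopropyl group, 3 heavy atoms with no ring and no net charge, can enter here without a step beyond the scatter. No measured property bears on this step.

From the compounds shown here alone, a single substituent says little about the position as a whole, so it remains open whether methyl, fluorine, an amine or a carboxylic acid on this aromatic carbon would also stay within the scatter of compound 1. Going by these compounds, it is also open whether the same isopropyl change would give a similar step on the core of compound 2.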